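This account rests on a few compounds, and the source may have more. Where it says the series, first, only, none or still open, it means among the compounds named here.

In a functional assay on CNE-2 cells (Homo sapiens) for cytotoxicity, read by sulforhodamine B assay, with a stated time of 48 h (a higher number here means a weaker inhibitor, a lower number a stronger inhibitor), compound 1 `COc1ccc(/C=C/C(=O)c2ccc(NC(C)=O)c(-c3ccc(F)cc3)c2)cc1OC` gives 2740 nM and compound 2 `COc1ccc(/C=C/C(=O)c2ccc(N)c(-c3ccc(F)cc3)c2)cc1` gives 1600 nM while compound 3 `O=C(/C=C/c1ccc(Br)cc1)c1cccc(-c2cccc(F)c2)c1` gives 10500 nM as the highest number of the three, beyond the scatter from both others. Compound 4 `O=C(/C=C/c1cccc(Br)c1)c1cccc(-c2cccc(F)c2)c1` has the same atoms joined differently, as 3-bromophenyl in place of 4-bromophenyl on a double-bonded chain carbon bound to a double-bonded chain carbon shows, with 3-bromophenyl in place of 4-bromophenyl on a double-bonded chain carbon bound to a double-bonded chain carbon. Within the data shown here, no measured pair shows such a change, so no shift beyond the scatter is expected, and the expected change is a 1.2-fold lower number from compound 3 to compound 4 (0.07 log units; within the scatter) in this assay alone. Compound 4 is estimated at 9000 nM within an expected range from 4000 nM to 22000 nM in this read-out.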

Compound 4, half-maximal inhibitory concentration: 6550 nM
Compound 4: the middle estimate sits 1.4-fold (0.14 log units) above what was measured; measured number inside the range.
By their numbers in this assay, from the lowest: compounds 2 and 1 (each within the scatter of the next); then compounds 4 and 3 (each within the scatter of the next).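

Among these compounds, the earlier compounds offered no pair differing in one place, so this is the first single change that can be read in this assay. Putting 3-bromophenyl in place of 4-bromophenyl on a double-bonded chain carbon bound to a double-bonded chain carbon gives a 1.6-fold lower number from compound 3 to compound 4 (0.20 log units; within the scatter) and so does not separate the two bromophenyl groups in this read-out. Nothing available accounts for this result.

As far as these compounds go, whether a nitrile or a carboxylic acid in place of the bromine would move the number beyond the scatter remains open. So does whether this change would read the same on the core of compound 1.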